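The compounds below may be only part of what the source reports. "The series", "measured", "known", "first", "only" and "open" are said of these compounds alone.

Compound 1 `C=CC1=C(C(=O)NCc2ccc(C)cc2)C(c2ccc(OC)cc2)OC1`: 43100 nM
Compound 2 `C=CC1=C(C(=O)NCc2ccc(C)cc2)C(c2ccc(F)cc2)OC1`: 62100 nM
Compound 3 `C=CC1=C(C(=O)O)C(c2ccc(OC)c(OC)c2)OC1`: a limit, > 100000 nM

The three measured compounds share one core and were tested in a functional assay on QGY7701 cells (Homo sapiens) for cytotoxicity, read by MTT assay, with a stated time of 24 h; on this read-out higher numbers stand for weaker inhibition and lower numbers for stronger inhibition. Compound 1 gives 43100 nM and compound 2 gives 62100 nM. For compound 3 this assay reports only a limit, > 100000 nM, so no number is known for it. Of the two numbers, compound 2 stands nearest compound 1, and the step of a 1.4-fold higher number from compound 1 to compound 2 (0.16 log units; within the scatter) lies within the scatter, so the two cannot be told apart.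

Compound 4 `C=CC1=C(C(=O)NC(C)(C)C)C(c2ccc(F)cc2)OC1` has not yet been measured. It differs from compound 2 in one place: tert-butyl in place of 4-methylbenzyl on an amide-type nitrogen. Going by the values given here, the only measured step, a 1.4-fold higher number from compound 1 to compound 2 (0.16 log units; within the scatter), concerns a group on an aromatic carbon, not the amide-type nitrogen, so it does not bear on this change; compound 3 differs from the others in more than one place and gives only a limit. With nothing measured at the amide-type nitrogen, the expectation is for no step beyond the scatter. Compound 4 is therefore estimated to give about 70000 nM, between 30000 nM and 150000 nM. This estimate means an expected step of a 1.1-fold higher number from compound 2 to compound 4 (0.05 log units; within the scatter).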

Compound 4, half-maximal inhibitory concentration: > 100000 nM
Compound 4: no number, only a limit (the forecaster's own chance of this, stated with the estimate: 30%); middle value at least 1.4-fold (0.15 log units) away from the limit.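

Going by these compounds alone, this is the first measurement in which the group on the amide-type nitrogen changes, and in this assay the swap of 4-methylbenzyl for tert-butyl gives an at least 1.6-fold higher number from compound 2 to compound 4 (0.20 log units; that floor lies within the scatter). Since only the lower bound of this step is known and it lies within the scatter, the result does not prove that this change weakens the effect on the cells, although it does show that compound 4 has no measured number in the range where compound 2 sits. In this assay compound 4 gives > 100000 nM, which is a limit and not a number, so the true size of the step stays hidden, and this ceiling is shared with another compound in the set: the limit of > 100000 nM in this assay, at which 2 of the 4 values shown sit.

The change removes the aromatic ring and also leaves fewer heavy atoms on the nitrogen, so the compounds shown cannot separate the loss of the ring from the loss of size. From the compounds shown here alone, a plain benzyl group or a straight butyl chain on that nitrogen would be needed to pull those two apart, and whether either would give a readable number remains open.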